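A few compounds are considered here, and "the series" means these few. Any claim that something is new, unique, unknown or untested is made for them only; others in the source may bear on it.

In a functional assay on A549 cells (Homo sapiens) for antiproliferative activity, read by MTT assay, with a stated time of 24 h; a higher number here means a weaker inhibitor, a lower number a stronger inhibitor:

Compound 1 `O=c1[nH]cc(S(=O)(=O)Nc2ccccc2-c2cn(-c3cccc(F)c3)nn2)c(=O)[nH]1`: 8130 nM
Compound 2 `O=c1[nH]cc(S(=O)(=O)Nc2ccccc2-c2cn(-c3ccc(F)cc3)nn2)c(=O)[nH]1`: 6390 nM
Compound 3 `O=c1[nH]cc(S(=O)(=O)Nc2ccc(-c3cn(-c4cccc(F)c4)nn3)cc2)c(=O)[nH]1`: 9980 nM

Among the measured compounds shown here, the only single-point change measured so far is 4-fluorophenyl in place of 3-fluorophenyl on an aromatic nitrogen, which gave a 1.3-fold lower number from compound 1 to compound 2 (0.10 log units; within the scatter). Compound 3 differs from compound 1 in its core; the difference between the two cores is not broken down here, and the two values stand within the scatter of each other.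

Compound 4 `O=c1[nH]cc(S(=O)(=O)Nc2ccc(-c3cn(-c4ccc(F)cc4)nn3)cc2)c(=O)[nH]1` carries the same change on the core of compound 3: 4-fluorophenyl in place of 3-fluorophenyl on an aromatic nitrogen. The place is described in the same words for both pairs, so this is taken as the same change.

Expected for compound 4 is a step of a 1.3-fold lower number from compound 3 to compound 4 (0.11 log units; within the scatter) in this assay, resting on the one earlier step of a 1.3-fold lower number from compound 1 to compound 2 (0.10 log units; within the scatter), which lay within the scatter. Compound 4 is therefore estimated at 7700 nM, with a range from 3800 nM to 15500 nM.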

Compound 4, half-maximal inhibitory concentration: 9720 nM
Estimate against measurement, compound 4: 1.3-fold (0.10 log units) below; measured number inside the range.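

In this assay, 4-fluorophenyl in place of 3-fluorophenyl on the aromatic nitrogen gives a 1.0-fold lower number from compound 3 to compound 4 (0.01 log units; within the scatter). The two cores show no difference in how this change reads: the same change on two cores in this assay, a 1.3-fold lower number (0.10 log units; within the scatter) from compound 1 to compound 2 and a 1.0-fold lower number (0.01 log units; within the scatter) from compound 3 to compound 4, 1.2-fold (0.09 log units) apart, within the scatter of two such steps. Among the compounds shown here, this shows only that the swap leaves the number within the scatter on both cores; with neither step resolved from the scatter, the agreement does not show that a step of real size would carry from one core to the other.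

Still open, as far as these compounds go, is how a 4-chlorophenyl, a 4-methoxyphenyl or a phenyl bearing an amine or a carboxylic acid would read on the aromatic nitrogen. Also open, from the compounds shown here alone, is whether any such step would exceed the scatter and hold on both cores.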